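Closing the diethylamino arm into a piperidine ring

This account rests on a few compounds, and the source may have more. Where it says the series, first, only, none or still open, it means among the compounds named here.

Among the measured compounds shown here, compound 1 `CCN(CC)CN1C(=O)/C(=N\c2nc3ccc(C)cc3s2)c2ccccc21` gives 20400 nM in an ADME assay on MCF-10A cells (Homo sapiens) for cytotoxicity, read by sulforhodamine B assay, with a stated time of 48 h (a lower number here means a stronger inhibitor of growth, a higher number a weaker inhibitor of growth), the highest of the two numbers measured so far; compound 2 `CCN(CC)CN1C(=O)/C(=N\c2nc3ccc(C)cc3s2)c2c(Br)cccc21` stands nearest, with 16100 nM, and the step of a 1.3-fold lower number from compound 1 to compound 2 (0.10 log units; within the scatter) came with bromo in place of hydrogen on an aromatic carbon. Compound 3 `Cc1ccc2nc(/N=C3\C(=O)N(CN4CCCCC4)c4ccccc43)sc2c1` carries piperidin-1-yl in place of diethylamino on a saturated chain carbon bound to an amide-type nitrogen in a ring. For the measured compounds named here, no measured step touches that arm; the only comparison available concerns the bromo change on the core. The account therefore expects no shift beyond the scatter, estimating a 1.0-fold lower number from compound 1 to compound 3 (0.01 log units; within the scatter). Compound 3 is expected to give 20000 nM, within 8000 nM to 50000 nM.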

Compound 3, concentration for 50% growth inhibition: 38900 nM
For compound 3 the middle estimate is 1.9-fold (0.29 log units) below the measured one; measured number inside the range.
By their numbers in this assay, from the lowest: compounds 2, 1 and 3 (each within the scatter of the next, the first and the last beyond it).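

On a saturated chain carbon bound to an amide-type nitrogen in a ring, replacing diethylamino with piperidin-1-yl gives a 1.9-fold higher number from compound 1 to compound 3 (0.28 log units; within the scatter) in this assay. Among the compounds shown here, this is the first measured change to that arm, and tying its ethyl chains into a ring leaves the result within the scatter. No available evidence bears on the cause of this result.

As far as these compounds go, whether a smaller pyrrolidin-1-yl ring or a morpholin-4-yl ring, with its added ring oxygen, would also stay within the scatter at this position remains open. So does the outcome of combining piperidin-1-yl with bromo on the shared core.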